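A few compounds are considered here, and "the series" means these few. Any claim that something is new, unique, unknown or untested is made for them only; others in the source may bear on it.

Compound 1 `CCCCOc1cc(C(C)(C)C)ccc1C/N=C(\S)NCc1ccc(NS(C)(=O)=O)cc1` gives 60 nM in a functional assay for inhibition of Vanilloid receptor (Rattus norvegicus) (a lower number here means a stronger inhibitor, a higher number a weaker inhibitor), the lowest of the two numbers measured. Among the compounds with values here, its only measured neighbour is compound 2 `CCCCCCOc1cc(C(C)(C)C)ccc1C/N=C(\S)NCc1ccc(NS(C)(=O)=O)cc1`, and compound 2 gives 150 nM; the step of a 2.5-fold higher number from compound 1 to compound 2 (0.40 log units; beyond the scatter) came from ethyl in place of hydrogen on a saturated chain carbon, four bonds along the chain from an oxygen on an aromatic ring. Compound 3 `CCCCOc1cc(C(C)(C)C)ccc1C/N=C(\S)NCc1ccc(NS(C)(=O)=O)c(F)c1` differs from compound 1 by fluoro in place of hydrogen on an aromatic carbon. No measured step touches this part of the molecule, so nothing shown points to a direction, and a step within the scatter is expected: a 1.1-fold lower number from compound 1 to compound 3 (0.04 log units; within the scatter). Compound 3 is estimated at 55 nM, between 20 nM and 150 nM.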

Compound 3, half-maximal inhibitory concentration: 20 nM
Compound 3: middle estimate off by 2.8-fold (0.44 log units), on the high side, within the range that was stated.
By their numbers in this assay, from the lowest: compound 3; then compound 1; then compound 2.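

In this assay, fluoro in place of hydrogen on the aromatic carbon ortho to the methanesulfonamido group gives a 3.0-fold lower number from compound 1 to compound 3 (0.48 log units; beyond the scatter) and so shows that this position, untouched by the earlier step, affects the result. The earlier step changed only the chain on the oxygen, whereas this one shows that a change on the methanesulfonamido-bearing ring can also give a stronger inhibitor. Nothing available explains this gain. From the compounds shown here alone, whether chloro or methyl at this carbon would do the same remains open. So does whether fluoro would bring a similar gain alongside the longer chain of compound 2.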